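Fluoro addition to compound 2: expectation notes

The source may hold more compounds than are shown below. What is called first, only, known or untested is meant among the compounds shown, and "the series" means these compounds.

In an assay on cells for inhibition of Palmitoleoyl-protein carboxylesterase NOTUM variant C330S (Homo sapiens), read by fluorescence, with a stated time of 40 min (a lower number here means a stronger inhibitor, a higher number a weaker inhibitor), compound 1 `Cc1cccc(-n2c(C)cc(C(=O)O)c2C)c1` gives 1500 nM, compound 2 `Cc1cc(C(=O)O)c(C)n1-c1cccc(C(C)C)c1` gives 360 nM and compound 3 `CCOc1cccc(-n2c(C)cc(C(=O)O)c2C)c1` gives 640 nM. Going by the values given here, compound 2 holds the lowest of the three numbers, though its gap to compound 3 is within the scatter, a 1.8-fold higher number from compound 2 to compound 3 (0.25 log units; within the scatter); only the steps of a 4.2-fold lower number from compound 1 to compound 2 (0.62 log units; beyond the scatter) and a 2.3-fold lower number from compound 1 to compound 3 (0.37 log units; beyond the scatter) lie beyond it. Compound 4 `Cc1cc(C(=O)O)c(C)n1-c1cccc(C(C)C)c1F` differs from compound 2 by fluoro in place of hydrogen on an aromatic carbon. Among the compounds with values here, no measured step replaces a hydrogen on this ring; the two steps beyond the scatter both exchange the group that is already present and say nothing about an added fluoro. Hence in this assay no step beyond the scatter is expected, a 1.1-fold lower number from compound 2 to compound 4 (0.04 log units; within the scatter). Compound 4 is therefore estimated at 330 nM, with a range of 120 nM to 900 nM.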

Compound 4, half-maximal inhibitory concentration: 150 nM
The estimate for compound 4 lay 2.2-fold (0.34 log units) above the measured number, and the stated range covers the measured number.
By their numbers in this assay, from the lowest: compound 4; then compounds 2 and 3 (each within the scatter of the next); then compound 1.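

The step of a 2.4-fold lower number from compound 2 to compound 4 (0.38 log units; beyond the scatter) in this assay comes with fluoro in place of hydrogen on an aromatic carbon, ortho to an isopropyl group. Going by these compounds alone, it is the only measured step that fills a hydrogen on this ring rather than exchanging a group already present, and it shows that this place can take a substituent with a lower number, not merely without loss. No evidence at hand bears on the origin of this step.

From the compounds shown here alone, whether a chloro or a methoxy group at this place would give a step of similar size remains open. Also open, going by these compounds, is whether fluoro gives the same step alongside the ethoxy group of compound 3 or the methyl group of compound 1.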